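A Smaller Oxygen-Bearing Aryl Group on the Core of Compound 1

The source may hold more compounds than are shown below. What is called first, only, known or untested is meant among the compounds shown, and "the series" means these compounds.

Compound 1 `COc1ccc(/C=N/NC(=O)Nc2ccc(Oc3ccnc(-c4nncn4CCN(C)C)c3)c(F)c2)c(OC)c1OC` stands highest of the two numbers measured in a functional assay on HT-29 cells (Homo sapiens) for cytotoxicity, read by MTT assay, with a stated time of 72 h (a higher number here means a weaker inhibitor, a lower number a stronger inhibitor), where compound 1 gives 3970 nM. Compound 2 `CN(C)CCn1cnnc1-c1cc(Oc2ccc(NC(=O)N/N=C/c3cccc(Br)c3)cc2F)ccn1` gives 380 nM in this assay, and a 10-fold lower number from compound 1 to compound 2 (1.02 log units; beyond the scatter). Compound 3 `COc1ccc(/C=N/NC(=O)Nc2ccc(Oc3ccnc(-c4nncn4CCN(C)C)c3)c(F)c2)cc1O` differs from compound 1 as follows: 3-hydroxy-4-methoxyphenyl in place of 2,3,4-trimethoxyphenyl on a carbon with a double bond to nitrogen. That single measured step bears on this change only loosely, since the group entering there was 3-bromophenyl rather than 3-hydroxy-4-methoxyphenyl; still, the one replacement of 2,3,4-trimethoxyphenyl seen so far lowered the number, so a moderate step toward a lower number is expected. Compound 3 is therefore expected to give 1500 nM, with a range from 400 nM to 6000 nM, meaning an expected step of a 2.6-fold lower number from compound 1 to compound 3 (0.42 log units; beyond the scatter).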

Compound 3, half-maximal inhibitory concentration: 960 nM
The estimate for compound 3 lay 1.6-fold (0.19 log units) above the measured number; the range from low to high includes it.
By their numbers in this assay, from the lowest: compound 2; then compound 3; then compound 1.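

In this assay, a second replacement of 2,3,4-trimethoxyphenyl on the carbon with a double bond to nitrogen also lowers the number (a 4.1-fold lower number from compound 1 to compound 3 (0.62 log units; beyond the scatter)), so the lowering no longer rests on 3-bromophenyl alone. The 3-hydroxy-4-methoxyphenyl group does not go as low as 3-bromophenyl, however (a 2.5-fold higher number from compound 2 to compound 3 (0.40 log units; beyond the scatter)). No measurement given here accounts for either step.

Going by these compounds, compound 3 changes the hydroxy and methoxy groups together, so which of these changes carries the step remains open. Also open, on these data alone, is how a phenyl ring bearing an amine or a carboxylic acid would compare at this place.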